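This account rests on a few compounds, and the source may have more. Where it says the series, first, only, none or still open, it means among the compounds named here.

In a functional assay on NCI-H460 cells (Homo sapiens) for inhibition, read by sulforhodamine B assay, with a stated time of 48 h (a lower number here means a stronger inhibitor of growth, a higher number a weaker inhibitor of growth), compound 1 `CC1=CC[C@H](C(C)(C)N=C=S)CC1` gives only a limit of the assay, > 100000 nM. Compound 2 `COc1ccc(/C=N/NC(=S)NC(C)(C)[C@H]2CC=C(C)CC2)cc1` carries a methyl on an oxygen on an aromatic ring at the far end of its thiosemicarbazone arm, and in this assay compound 2 gives 47800 nM. Compound 3 `CC1=CC[C@H](C(C)(C)NC(=S)N/N=C/c2ccc(O)cc2)CC1` differs from compound 2 only by hydrogen in place of methyl on that oxygen. In this assay compound 3 reaches only a limit of the assay, > 100000 nM. The one measured step, an at least 2.0-fold higher number from compound 2 to compound 3 (0.32 log units; beyond the scatter), ends at the limit of > 100000 nM in this assay, at which 2 of the 3 values shown sit, so compound 3 stands at the weak end of everything shown, as a limit rather than a number.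

Compound 4 `CC1=CC[C@H](C(C)(C)NC(=S)N/N=C/c2ccc[nH]2)CC1` differs from compound 3 by 1H-pyrrol-2-yl in place of 4-hydroxyphenyl on a carbon with a double bond to nitrogen. Among the measured compounds shown here, no measured step exchanges one aromatic ring for another, so the step from compound 2 to compound 3 offers no direct guide to this change. Compound 4 is therefore expected to stay close to compound 3, with an estimated step of a number no higher from compound 3 to compound 4 (the limit leaves the size open). The estimate for compound 4 in this assay is 100000 nM, within a range from 30000 nM to 400000 nM.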

Compound 4, concentration for total growth inhibition: 57500 nM
Compound 4: middle estimate off by 1.7-fold (0.24 log units), on the high side, within the range that was stated.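

Exchanging 4-hydroxyphenyl for 1H-pyrrol-2-yl gives a measured number where there was only a limit in this assay, with an at least 1.7-fold lower number from compound 3 to compound 4 (0.24 log units; that floor lies within the scatter). The true size of that step stays open because the value of compound 3 is a limit of the assay and not a number: the limit of > 100000 nM in this assay, at which 2 of the 4 values shown sit.

The comparison with a number at both ends is a 1.2-fold higher number from compound 2 to compound 4 (0.08 log units; within the scatter), so in this assay the five-membered ring and 4-methoxyphenyl cannot be told apart at this place.

The compounds shown leave open whether another ring here, such as a furan or a pyridine, would give a number beyond the scatter from those of compound 2 and compound 4. They also leave open what an amine on the phenyl ring would do.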